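A few compounds are considered here, and "the series" means these few. Any claim that something is new, unique, unknown or untested is made for them only; others in the source may bear on it.

Measured so far:
- compound 1 `CN(C[C@@H]1Cc2c(cccc2N2CCNCC2)CN1)[C@H]1CCCc2cccnc21`: 94.2%
- compound 2 `CN(C[C@H]1Cc2c(cccc2N2CCN(C3COC3)CC2)CN1)[C@H]1CCCc2cccnc21`: 83.1%

Both compounds were tested in an ADME assay on microsomes from liver (Homo sapiens) for metabolic stability, read by LC-MS, with a stated time of 10 min; a lower number here means that less of the compound is left, a higher number that more of the compound is left. Compound 1 gives 94.2%, and compound 2 gives 83.1%, the lower of the two numbers; the gap between them is beyond the usual scatter, so compound 2 stands clearly below compound 1 here.

Compound 3 `CC(C)N1CCN(c2cccc3c2C[C@H](CN(C)[C@H]2CCCc4cccnc42)NC3)CC1` is not yet measured. It differs from compound 2 in one place: isopropyl in place of oxetan-3-yl on an amine nitrogen in a ring. Going by the values given here, no pair of measured compounds shows this change, so its size is unknown from the data. The expectation is a small step downward in this assay , of a size that may well stay within the scatter. The change is estimated to amount to a number 8.1 percentage points lower from compound 2 to compound 3 (within the scatter). Compound 3 is therefore expected to give about 75%, in a range from 55% to 92%.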

Compound 3, percent of the compound remaining: 56.6%
Estimate against measurement, compound 3: 18.4 percentage points above; measured number inside the range.
By their numbers in this assay, from the lowest: compound 3; then compound 2; then compound 1.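

Going by these compounds alone, compound 2 and compound 3 differ only in the group on an amine nitrogen in a ring, so this pair gives the first clean reading of a single change at this position. In this assay putting isopropyl in place of oxetan-3-yl gives a number 26.5 percentage points lower from compound 2 to compound 3 (beyond the scatter) and so shows that this position is not indifferent to the group it carries. The oxetan-3-yl group has a four-membered ring with one oxygen, and isopropyl has neither ring nor oxygen, but this single pair cannot show which of these differences matters.

Going by these compounds, it remains open how a methyl group, a longer chain such as n-butyl, or an oxygen-bearing open chain such as 2-methoxyethyl on the same nitrogen would compare. Nothing measured here gives a reason for the drop.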